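Sulfonate for Ester: Cytotoxicity Expected to Stay Beyond Limit

The source may hold more compounds than are shown below. What is called first, only, known or untested is meant among the compounds shown, and "the series" means these compounds.

Three compounds have been measured in an ADME assay on Vero cells (Chlorocebus sabaeus) for cytotoxicity, read by MTT assay, with a stated time of 48 h; on this read-out higher numbers stand for weaker inhibition and lower numbers for stronger inhibition; each of the three values is a limit of the assay rather than a number:
compound 1 `CC(C)S(=O)(=O)OC1CCC(CN2CCN(c3cc(=O)c4cc(C(F)(F)F)cc([N+](=O)[O-])c4s3)CC2)CC1`: > 64 ug/mL
compound 2 `O=C(OC1CCC(CN2CCN(c3cc(=O)c4cc(C(F)(F)F)cc([N+](=O)[O-])c4s3)CC2)CC1)c1cccc(C(F)(F)F)c1`: > 64 ug/mL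
compound 3 `O=C(OC1CCC(CN2CCN(c3cc(=O)c4cc(C(F)(F)F)cc([N+](=O)[O-])c4s3)CC2)CC1)c1ccc(C(F)(F)F)cc1`: > 64 ug/mL

Compound 3 therefore stands only at a limit in this assay, and the two other values shown are limits as well (the limit of > 64 ug/mL in this assay, at which 3 of the 3 values shown sit). Within the data shown here, compound 4 `O=c1cc(N2CCN(CC3CCC(OS(=O)(=O)c4ccc5c(c4)CCO5)CC3)CC2)sc2c([N+](=O)[O-])cc(C(F)(F)F)cc12` differs from compound 3 in one place: a group of 12 heavy atoms (8 carbon, 3 oxygen, 1 sulfur; one five-membered non-aromatic ring with 1 hetero atom, one six-membered aromatic ring of carbon only) in place of a group of 12 heavy atoms (8 carbon, 1 oxygen, 3 fluorine; one six-membered aromatic ring of carbon only), on an oxygen on a saturated carbon The steps that bear on this change are a step that the two limits leave unreadable from compound 1 to compound 3 and a step that the two limits leave unreadable from compound 2 to compound 3, together with a step that the two limits leave unreadable from compound 1 to compound 2; none of them can be read in size, because every value sits at the same limit (the limit of > 64 ug/mL in this assay, at which 3 of the 3 values shown sit). Compound 1 carries an isopropylsulfonyl group on an oxygen on a saturated carbon, as compound 4 carries its sulfonyl group, and compound 1 reaches the limit. With all three measured compounds at the limit, no step beyond the scatter is expected in either direction for compound 4. Compound 4 is therefore expected to give 64 ug/mL, with a range from 40 ug/mL to 100 ug/mL, most likely again reported only as a limit. The expected step is a number no higher from compound 3 to compound 4 (the limit leaves the size open).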

Compound 4, half-maximal inhibitory concentration: > 64 ug/mL
Compound 4 ended at the assay's limit (the forecaster's own chance of this, stated with the estimate: 80%); the middle value sits exactly at the limit.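

The steps from compound 1, compound 2 and compound 3 to compound 4 cannot be read in size, because all four compounds sit at the same limit in this assay: the limit of > 64 ug/mL in this assay, at which 4 of the 4 values shown sit.

Left open is where the true value of each compound lies, and whether exchanging the groups on that oxygen changes the cytotoxicity at all.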